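This account rests on a few compounds, and the source may have more. Where it says the series, first, only, none or still open, it means among the compounds named here.

Measured so far:
compound 1 `COc1cccc(C(=O)Oc2cc3c(cc2C)[C@@H](C(C)C)CC=C3C)c1` — 24.2%
compound 2 `CC1=CC[C@H](C(C)C)c2cc(C)c(OC(=O)c3ccc(C)cc3)cc21` — 85.4%

In a functional assay on SK-LU-1 cells (Homo sapiens) for antiproliferative activity, read by sulforhodamine B assay, with a stated time of 48 h, tested at 50 uM (on this read-out lower numbers stand for less inhibition and higher numbers for more inhibition at the one concentration tested (going by the name of the read-out)), compound 1 gives 24.2%, while compound 2 gives 85.4%. Compound 2 thus stands at the top of the two numbers recorded; the step between them is a number 61.2 percentage points higher from compound 1 to compound 2 (beyond the scatter), which lies beyond the scatter and shows that the group on the carbonyl carbon governs the read-out strongly in this pair.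

Compound 3 `CC1=CC[C@H](C(C)C)c2cc(C)c(OC(=O)Nc3ccccc3)cc21` has not yet been measured in this assay. Against compound 2 the change is anilino in place of 4-methylphenyl on a carbonyl carbon. For the measured compounds named here, the only measured step, from compound 1 to compound 2, also exchanges the group on the carbonyl carbon, and it was large; it does not, however, contain an anilino group, so its direction cannot be carried over directly. A step of some size in either direction is therefore plausible, with the high number of compound 2 leaving more room downward. For compound 3 the expected value in this assay is 55%, with a range of 15% to 88%. This estimate means a step of a number 30.4 percentage points lower from compound 2 to compound 3 (beyond the scatter) from compound 2.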

Compound 3, a percentage reported as inhibition, at one concentration (the size of the read-out at that concentration, not a potency): 100%
For compound 3 the middle estimate is 45 percentage points below the measured one; the whole stated range lies below it.
By their numbers in this assay, from the lowest: compound 1; then compound 2; then compound 3.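

In this assay, the carbonyl carbon bonded to oxygen accepts an anilino group, which carries a hydrogen-bond donor that 4-methylphenyl lacks, with a modest gain: a number 14.6 percentage points higher from compound 2 to compound 3 (beyond the scatter). For the compounds shown here, the larger change, a number 75.8 percentage points higher from compound 1 to compound 3 (beyond the scatter), leaves 3-methoxyphenyl as the only one of the three groups with a low number, so a high read-out at this position is not confined to one group. Nothing measured explains either step.

Open, from the compounds shown here alone, is whether the gain needs the hydrogen on the anilino nitrogen, which a methylated anilino group would test, and whether it needs the aromatic ring, which a cyclohexylamino group would test. A single-concentration read-out also leaves the potency of these compounds undefined.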